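Pyridin-4-yl in Place of Difluorophenyl at the Ring Amine

The compounds below may be only part of what the source reports. "The series", "measured", "known", "first", "only" and "open" are said of these compounds alone.

Of the compounds shown here, three sharing one core have been measured in an assay on HEK293 cells for agonist activity at Toll-like receptor 8 (Homo sapiens), read by a luciferase reporter, with a stated time of 6 h; a lower number here means that less compound is needed, a higher number that more compound is needed for the effect. Compound 1 `CCCCNc1nc(N)nc2c1CN(Cc1ccccc1)CC2` gives 0.06 uM, compound 2 `CCCCNc1nc(N)nc2c1CN(C(C)=O)CC2` gives 0.5 uM and compound 3 `CCCCNc1nc(N)nc2c1CN(Cc1cc(F)cc(F)c1)CC2` gives 0.23 uM. Compound 3 stands second highest of the three, below compound 2 and above compound 1. Compound 4 `CCCCNc1nc(N)nc2c1CN(Cc1ccncc1)CC2` differs from compound 3 by pyridin-4-yl in place of 3,5-difluorophenyl on a saturated chain carbon bound to an amine nitrogen in a ring. Among the compounds with values here, the steps that bear on it are a 3.8-fold higher number from compound 1 to compound 3 (0.58 log units; beyond the scatter) and an 8.3-fold higher number from compound 1 to compound 2 (0.92 log units; beyond the scatter), showing that the group on that carbon shifts the number modestly while an aryl group appears to be favourable. With the fluorines gone and a ring nitrogen entering, a modest drop toward compound 1 is expected, a 2.3-fold lower number from compound 3 to compound 4 (0.36 log units; beyond the scatter). Compound 4 is therefore estimated at 0.1 uM, between 0.03 uM and 0.4 uM.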

Compound 4, minimum effective concentration: 0.29 uM
For compound 4 the middle estimate is 2.9-fold (0.46 log units) below the measured one; measured number inside the range.
By their numbers in this assay, from the lowest: compound 1; then compounds 3, 4 and 2 (each within the scatter of the next, the first and the last beyond it).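

In this assay the step to pyridin-4-yl, a 1.3-fold higher number from compound 3 to compound 4 (0.10 log units; within the scatter), leaves the two ring groups unseparated, and a 1.7-fold lower number from compound 2 to compound 4 (0.24 log units; within the scatter) leaves the acetyl of compound 2 unseparated from (pyridin-4-yl)methyl as well. Only the plain benzyl of compound 1 stands apart, with a 4.8-fold higher number from compound 1 to compound 4 (0.68 log units; beyond the scatter), so the earlier reading that an aryl group favours the effect holds for phenyl alone, not for every aryl group shown. No evidence on the cause of these results is available. Open, going by these compounds, is whether pyridin-3-yl or pyridin-2-yl would behave like pyridin-4-yl. Also open, on these data alone, is whether a single fluorine or a methoxy on the phenyl would keep the number of compound 1.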